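Para-substituent on the phenyl ring: chloro to methyl

The compounds below may be only part of what the source reports. "The series", "measured", "known", "first", "only" and "open" are said of these compounds alone.

Measured so far, in a functional assay on MCF7 cells (Homo sapiens) for antiproliferative activity, read by MTT assay, with a stated time of 96 h; on this read-out higher numbers stand for weaker inhibition and lower numbers for stronger inhibition:
- compound 1 `O=C1C2=C(C(=O)c3ncccc31)C1(CS2)NC(=O)N(c2ccc(Cl)cc2)C1=O`: 4 nM
- compound 2 `O=C1C2=C(C(=O)c3ncccc31)C1(CS2)NC(=O)N(c2ccc([N+](=O)[O-])cc2)C1=O`: 350 nM
- compound 3 `O=C1C2=C(C(=O)c3ncccc31)C1(CS2)NC(=O)N(c2ccccc2)C1=O`: 1 nM

Compound 1 stands second highest of the three numbers. Its nearest neighbour is compound 3, reached by a 4.0-fold lower number from compound 1 to compound 3 (0.60 log units; beyond the scatter); the furthest is compound 2, reached by an 88-fold higher number from compound 1 to compound 2 (1.94 log units; beyond the scatter). Between those two, a 350-fold lower number from compound 2 to compound 3 (2.54 log units; beyond the scatter) closes the set.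

Compound 4 `Cc1ccc(N2C(=O)NC3(CSC4=C3C(=O)c3ncccc3C4=O)C2=O)cc1` is not yet measured. It differs from compound 1 in one place: methyl in place of chloro on an aromatic carbon. Going by the values given here, no measured step replaces chloro with methyl on this aromatic carbon, so only the two steps that leave compound 1 at the same place bear on it. One of them, to compound 3, was modest and downward; the other, to compound 2, was large and upward. Methyl is neither of these groups, and the shared core is unchanged, so the expectation for compound 4 is a number close to that of compound 1, with the step of a 1.3-fold lower number from compound 1 to compound 4 (0.12 log units; within the scatter) expected to stay within or near the scatter. The estimate for compound 4 is 3 nM, with a range from 1 nM to 12 nM.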

Compound 4, half-maximal inhibitory concentration: 2 nM
Beside the measured number, compound 4's estimate is 1.5-fold (0.18 log units) above it, and the stated range covers the measured number.
By their numbers in this assay, from the lowest: compounds 3, 4 and 1 (each within the scatter of the next, the first and the last beyond it); then compound 2.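

In this assay, methyl on this aromatic carbon cannot be told apart from chloro, with a 2.0-fold lower number from compound 1 to compound 4 (0.30 log units; within the scatter), or from hydrogen, with a 2.0-fold higher number from compound 3 to compound 4 (0.30 log units; within the scatter), although compound 1 and compound 3 lie beyond the scatter of each other. Against nitro the picture is different, with a 180-fold lower number from compound 2 to compound 4 (2.24 log units; beyond the scatter), so compound 2 remains the only compound of the four set well apart from the rest, and a carbon-based group at this place now sits with the low numbers. Nothing at hand accounts for the separate position of nitro.

On these data alone, whether compound 2 reflects nitro alone or extends to groups such as a nitrile, a carboxylic acid or an amine remains open. Also open, as far as these compounds go, is whether the low numbers hold for a longer chain than methyl, such as ethyl or butyl.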